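4-Fluorobenzyl to 4-nitrobenzyl: the next step in the series

The source may hold more compounds than are shown below. What is called first, only, known or untested is meant among the compounds shown, and "the series" means these compounds.

Values in a functional assay on Bel-7402 cells (Homo sapiens) for antiproliferative activity, read by MTT assay, with a stated time of 72 h; a higher number here means a weaker inhibitor, a lower number a stronger inhibitor:
- compound 1 `C=C1C(=O)O[C@H]2[C@H]1CC/C(COC(=O)Cn1cc(F)c(=O)[nH]c1=O)=C\CC[C@@]1(C)O[C@@H]21`: > 20000 nM (a limit of the assay, not a number)
- compound 2 `C=C1C(=O)O[C@H]2[C@H]1CC/C(COC(=O)Cn1cc(F)c(=O)n(Cc3ccc(F)cc3)c1=O)=C\CC[C@@]1(C)O[C@@H]21`: 2730 nM

Within the data shown here, compound 2, at 2730 nM, holds the only number so far in this assay. The other entry is a limit, that of compound 1: the limit of > 20000 nM in this assay, at which 1 of the 2 values shown sits.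

Among the measured compounds shown here, the one measured step is an at least 7.3-fold lower number from compound 1 to compound 2 (0.86 log units; beyond the scatter), with 4-fluorobenzyl in place of hydrogen on an aromatic nitrogen.

Compound 3 `C=C1C(=O)O[C@H]2[C@H]1CC/C(COC(=O)Cn1cc(F)c(=O)n(Cc3ccc([N+](=O)[O-])cc3)c1=O)=C\CC[C@@]1(C)O[C@@H]21` differs from compound 2 by nitro in place of fluoro on an aromatic carbon, para to a large group: nitro in place of fluoro on an aromatic carbon. For the measured compounds named here, no measured step exchanges fluoro for another group. The step from the hydrogen compound to the benzyl compound concerns a different change, so it sets neither the size nor the direction of this one. Only a small step is therefore expected, with wide uncertainty on both sides, and the value of compound 2 at 2730 nM serves as the anchor.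

The expected change is a 1.1-fold lower number from compound 2 to compound 3 (0.04 log units; within the scatter), an estimate that may well stay within the scatter.

For compound 3 the estimated value is 2500 nM, with an expected range from 900 nM to 7000 nM.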

Compound 3, half-maximal inhibitory concentration: 4070 nM
For compound 3 the middle estimate is 1.6-fold (0.21 log units) below the measured one; low and high end bracket the measured number.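

In this assay, nitro in place of fluoro on an aromatic carbon, para to a large group, gives a 1.5-fold higher number from compound 2 to compound 3 (0.17 log units; within the scatter), so the two groups cannot be told apart at this position, even though nitro is the larger group by heavy-atom count and brings hydrogen-bond acceptors that fluoro lacks. The gain from substituting the aromatic nitrogen recurs with a second benzyl group, as an at least 4.9-fold lower number from compound 1 to compound 3 (0.69 log units; beyond the scatter) shows, which means it is not tied to 4-fluorobenzyl alone. Compound 1 marks a limit of the assay, not a number, and both steps from it therefore give only a minimum size: the limit of > 20000 nM in this assay, at which 1 of the 3 values shown sits.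

Among these compounds, only two groups have been seen at this position, so it remains open whether an amine, a methoxy group or a carboxylic acid in the same place would move the number beyond the scatter. Also open, on these data alone, are the plain benzyl group, without a substituent on the aromatic ring, and a longer chain between the aromatic nitrogen and the aromatic ring.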